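The source may hold more compounds than are shown below. What is called first, only, known or untested is meant among the compounds shown, and "the series" means these compounds.

Working notes on the series, all compounds sharing one core. In an ADME assay (liver) for metabolic stability, with Liver microsome (Rattus norvegicus) as the target, using microsomes (a lower number here means slower removal, a higher number faster removal of the compound), compound 1 (`CC[C@@H](Nc1nnc(-c2c[nH]c3ncccc23)o1)c1ccccc1`) gives 29 mL.min-1.g-1 and compound 2 (`CC(C)[C@@H](Nc1nnc(-c2c[nH]c3ncccc23)o1)c1ccccc1`) gives 51 mL.min-1.g-1. Among the compounds with values here, compound 2 therefore stands within the scatter of compound 1, the only other compound measured so far.

The next compound, compound 3 (`c1ccc([C@H](Nc2nnc(-c3c[nH]c4ncccc34)o2)C2CC2)cc1`), has cyclopropyl in place of isopropyl on a saturated chain carbon bound to an aromatic carbon and a nitrogen on an aromatic ring. Within the data shown here, no measured step exchanges an open chain for a ring, so there is no direct precedent for this change.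

Among the measured compounds shown here, the only guide is a 1.8-fold higher number from compound 1 to compound 2 (0.25 log units; within the scatter), which is methyl in place of hydrogen on a saturated chain carbon bound to two saturated chain carbons. Resting on that small step, no move beyond the scatter is expected in this assay, and no firm direction can be assigned. The expected step is a 1.3-fold lower number from compound 2 to compound 3 (0.13 log units; within the scatter). For compound 3 the estimated value is 38 mL.min-1.g-1, with an expected range of 18 mL.min-1.g-1 to 80 mL.min-1.g-1.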

Compound 3, intrinsic clearance in microsomes: 31 mL.min-1.g-1
For compound 3 the middle estimate is 1.2-fold (0.09 log units) above the measured one; the measured number falls inside the stated range.
By their numbers in this assay, from the lowest: compounds 1, 3 and 2 (each within the scatter of the next).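

In this assay, within the data shown here, cyclopropyl in place of isopropyl on a saturated chain carbon bound to an aromatic carbon and a nitrogen on an aromatic ring gives a 1.6-fold lower number from compound 2 to compound 3 (0.22 log units; within the scatter), the first reading of an open chain exchanged for a three-membered non-aromatic ring of carbon only at this position. The same ring in place of ethyl gives a 1.1-fold higher number from compound 1 to compound 3 (0.03 log units; within the scatter), so ethyl, isopropyl and cyclopropyl all lie within the scatter of one another here, and introducing this ring does not separate compound 3 from either open-chain compound. No supporting data are available to explain these small steps.

On these data alone, the three compounds cover only small carbon-only groups at this position, so it remains open whether a longer chain, an amine or a carboxylic acid there would shift the number beyond the scatter. As far as these compounds go, how far the number depends on this position compared with the rest of the shared core also remains open, as all three compounds differ only in this one group.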